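A few compounds are considered here, and "the series" means these few. Any claim that something is new, unique, unknown or untested is made for them only; others in the source may bear on it.

Measured compounds:
compound 1 `CC(C)n1ncc2c(C(=O)Nc3cccnc3)cc(-c3cccs3)nc21` — > 200000 nM
compound 2 `CC(C)n1ncc2c(C(=O)Nc3cccnc3)cc(-c3ccsc3)nc21` — 37000 nM
compound 3 `CC(C)n1ncc2c(C(=O)Nc3cccc(S(=O)(=O)N(C)C)c3)cc(-c3cccs3)nc21` — > 200000 nM

In an ADME assay on LLC-MK2 cells (Macaca mulatta) for cytotoxicity, read by spectrophotometry and crystal violet staining, with a stated time of 4 days (a lower number here means that less compound is tolerated, a higher number that more compound is tolerated), compound 1 returns only a limit, > 200000 nM. Compound 3 likewise returns a limit, > 200000 nM. Among the compounds with values here, compound 2 gives a number, 37000 nM, and an at least 5.4-fold lower number from compound 1 to compound 2 (0.73 log units; beyond the scatter) is the only step within the measured set; it concerns a different part of the structure and does not bear on the change considered here.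

Compound 4 `CC(C)n1ncc2c(C(=O)Nc3ncccn3)cc(-c3cccs3)nc21` differs from compound 1 by pyrimidin-2-yl in place of pyridin-3-yl on an amide-type nitrogen. Within the data shown here, no measured step covers an exchange on the amide-type nitrogen, so nothing in the numbers points in either direction. Given (the limit of > 200000 nM in this assay, at which 2 of the 3 values shown sit), compound 4 is expected to remain at that limit as well, estimated at 200000 nM (range 100000 nM to 400000 nM), which corresponds to an expected step of a number no higher from compound 1 to compound 4 (the limit leaves the size open).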

Compound 4, half-maximal cytotoxic concentration: 75000 nM
Compound 4: middle estimate off by 2.7-fold (0.43 log units), on the high side; the measured number lies below the stated range.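

Within the data shown here, this is the first measured exchange on the amide-type nitrogen, and in this assay it is not silent (an at least 2.6-fold lower number from compound 1 to compound 4 (0.42 log units; beyond the scatter)). The number can therefore move off the ceiling through this position, as well as through the thiophene attachment, although that ceiling is common in this set: the limit of > 200000 nM in this assay, at which 2 of the 4 values shown sit.
The value of compound 1 is a limit, so only the minimum size of this step can be read.

Open, from the compounds shown here alone, is whether pyridin-2-yl or a simple phenyl on the amide-type nitrogen would give a similar drop. Also open, going by these compounds, is whether pyrimidin-2-yl behaves the same way alongside thiophen-3-yl.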